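A Hydroxy Group on the Side Chain of Compound 1

This account rests on a few compounds, and the source may have more. Where it says the series, first, only, none or still open, it means among the compounds named here.

Compound 1 `C[C@H](NC(=O)CN(c1nc(Cl)nc2c1ncn2C1CCCCO1)C1CC1)C(=O)OCc1ccccc1`: 32.1%
Compound 2 `CC[C@H](C)[C@H](NC(=O)CN(c1nc(Cl)nc2c1ncn2C1CCCCO1)C1CC1)C(=O)OCc1ccccc1`: 22.6%

Within the data shown here, in a functional assay on the whole organism with Mus musculus as the target, with a stated time of 90 min, at a dose of 25 umol/kg by the oral route (a higher number here means a stronger effect of the compound at the dose given, a lower number a weaker effect), compound 1 is the reference point of this small set; the only measured comparison, a number 9.5 percentage points lower from compound 1 to compound 2 (within the scatter), lies within the scatter, so the two numbers cannot be told apart. Compound 3 `O=C(CN(c1nc(Cl)nc2c1ncn2C1CCCCO1)C1CC1)N[C@@H](CO)C(=O)OCc1ccccc1` differs from compound 1 by hydroxy in place of hydrogen on a saturated chain carbon, two bonds along the chain from an amide-type nitrogen and a carbonyl carbon. Among the measured compounds shown here, the single measured step concerns a different group at the same chain carbon and gave no movement beyond the scatter, so it offers no direct guide. The expected step is therefore small, a number 3.1 percentage points lower from compound 1 to compound 3 (within the scatter). Compound 3 is estimated at 29%, within 14% to 44%.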

Compound 3, a percentage reported as activity, at one dose (the size of the read-out at that dose, not a potency): 32.2%
Compound 3: the middle estimate sits 3.2 percentage points below what was measured, within the range that was stated.
By their numbers in this assay, from the lowest: compounds 2, 1 and 3 (each within the scatter of the next).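

In this assay hydroxy in place of hydrogen on this chain carbon gives a number 0.1 percentage points higher from compound 1 to compound 3 (within the scatter) and so adds no measurable change to the effect at this dose. Hydroxymethyl in place of sec-butyl gives a number 9.6 percentage points higher from compound 2 to compound 3 (within the scatter) and this shows that even these two differently sized side chains cannot be told apart here, so the position has not yet shown any response to the group it carries. Nothing available explains why these numbers stay together.

The compounds shown leave open whether an amine or a carboxylic acid on this chain carbon would move the effect beyond the scatter. They also leave open whether a longer chain ending in hydroxy would do so.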